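Compound 2 to compound 3: dimethylamino for pyrrolidin-1-yl

The compounds below may be only part of what the source reports. "The series", "measured", "known", "first", "only" and "open" are said of these compounds alone.

Compound 1 (`CCOC(=O)N(C)C(C)C#CCn1cncc1C`) gives > 100 mg/kg as a limit of the assay
Compound 2 (`Cn1ccn(CC#CCN2CCCC2)c1=O`) gives 6.6 mg/kg as a number

For the measured compounds named here, in a functional assay on the whole organism for agonist activity, with Mus musculus as the target (a higher number here means that more compound is needed for the effect, a lower number that less compound is needed), compound 2 gives 6.6 mg/kg and this is the only number so far. Compound 3 (`CN(C)CC#CCn1ccn(C)c1=O`) differs from compound 2 by dimethylamino in place of pyrrolidin-1-yl on a saturated chain carbon bound to a triple-bonded carbon with dimethylamino in place of pyrrolidin-1-yl on a saturated chain carbon bound to a triple-bonded carbon. Going by the values given here, no measured pair shows this change. In this assay a modest rise in the dose needed is expected, perhaps not beyond the usual scatter. The expected change is a 1.5-fold higher number from compound 2 to compound 3 (0.18 log units; within the scatter) on this estimate. For compound 3 the estimated value is 10 mg/kg with an expected range from 3 mg/kg to 35 mg/kg for the coming measurement.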

Compound 3, dose for half-maximal effect: 8 mg/kg
For compound 3 the middle estimate is 1.3-fold (0.10 log units) above the measured one; the range from low to high includes it.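

In this assay, for the compounds shown here, this pair gives the first direct reading of a change on a saturated chain carbon bound to a triple-bonded carbon: a 1.2-fold higher number from compound 2 to compound 3 (0.08 log units; within the scatter). In this pair, the open-chain dimethylamino serves as well as pyrrolidin-1-yl, so the five-membered ring is not required for a measurable dose. Nothing shown gives a cause for this step.

Still open, from the compounds shown here alone, is how other amines, such as piperidin-1-yl or a primary amine, behave at this place. Also open, going by these compounds, is whether a longer saturated chain carrying the amine is tolerated.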